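A few compounds are considered here, and "the series" means these few. Any claim that something is new, unique, unknown or untested is made for them only; others in the source may bear on it.

In a functional assay on 1A9 cells (Homo sapiens) for cytotoxicity; on this read-out higher numbers stand for an effect only at larger amounts of compound and lower numbers for an effect already at smaller amounts:
- Compound 1 `COC1=C(C)C(=O)/C(=C(O)/C=C/c2ccc(Br)cc2)C(=O)C1(C)C`: 1.1 ug/mL
- Compound 2 `COC1=C(C)C(=O)/C(=C(O)/C=C/c2ccco2)C(=O)C1(C)C`: 7.9 ug/mL

Compound 2 has the higher of the two numbers. Compound 3 `COC1=C(C)C(=O)/C(=C(O)/C=C/c2nccs2)C(=O)C1(C)C` has 1,3-thiazol-2-yl in place of furan-2-yl on a double-bonded chain carbon bound to a double-bonded chain carbon. For the measured compounds named here, one measured step touches this place, a 7.2-fold higher number from compound 1 to compound 2 (0.86 log units; beyond the scatter). That modest step, beyond the scatter, replaced 4-bromophenyl, a different exchange, so it shows that this place matters but gives no direction here. Only a small change is therefore expected, a 1.3-fold lower number from compound 2 to compound 3 (0.12 log units; within the scatter). The estimated value for compound 3 is 6 ug/mL, within a range of 2.2 ug/mL to 16 ug/mL.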

Compound 3, concentration for half-maximal effect: 3.5 ug/mL
Beside the measured number, compound 3's estimate is 1.7-fold (0.23 log units) above it; the measured number falls inside the stated range.
By their numbers in this assay, from the lowest: compound 1; then compound 3; then compound 2.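

Exchanging one five-membered aromatic ring for another at this place still moves the result in this assay, with a 2.3-fold lower number from compound 2 to compound 3 (0.35 log units; beyond the scatter), although both groups have 5 heavy atoms. The 4-bromophenyl group keeps the lowest number, with a 3.2-fold higher number from compound 1 to compound 3 (0.50 log units; beyond the scatter), so 1,3-thiazol-2-yl recovers only part of the gap between compound 1 and compound 2. Nothing available explains the difference between these groups. The compounds shown leave open how an unsubstituted phenyl or a ring carrying an amine would compare at this place.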